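The source may report more compounds than this note shows. Statements on the series, on what has been measured and on what is new or still open speak of the compounds shown alone.

Measured in an ADME assay on L02 cells (Homo sapiens) for antiproliferative activity, read by MTT assay, with a stated time of 48 h; a higher number here means a weaker inhibitor, a lower number a stronger inhibitor:
compound 1 `Cc1cccc(-n2nncc2CN2C(=O)C3(C(C#N)=C(N)Oc4c(N)cc5nc6ccccc6nc5c43)c3ccccc32)c1`: > 50000 nM, a limit of the assay
compound 2 `COc1ccccc1-n1nncc1CN1C(=O)C2(C(C#N)=C(N)Oc3c(N)cc4nc5ccccc5nc4c32)c2ccccc21`: > 50000 nM, a limit of the assay
compound 3 `CCc1cccc(C)c1-n1nncc1CN1C(=O)C2(C(C#N)=C(N)Oc3c(N)cc4nc5ccccc5nc4c32)c2ccccc21`: > 50000 nM, a limit of the assay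

Among the measured compounds shown here, compound 3 stands at the limit of this assay, where the whole series sits: no compound returns a number. The steps a step that the two limits leave unreadable from compound 1 to compound 2, a step that the two limits leave unreadable from compound 1 to compound 3 and a step that the two limits leave unreadable from compound 2 to compound 3 cannot be sized, since each joins two limits. What the series offers is only (the limit of > 50000 nM in this assay, at which 3 of the 3 values shown sit).

Compound 4 `Cc1ccc(Cl)cc1-n1nncc1CN1C(=O)C2(C(C#N)=C(N)Oc3c(N)cc4nc5ccccc5nc4c32)c2ccccc21` is not yet measured. Change from compound 3: 5-chloro-2-methylphenyl in place of 2-ethyl-6-methylphenyl on an aromatic nitrogen. The measured steps bear on this change only indirectly: each exchange of the group on the aromatic nitrogen among compounds 1, 2 and 3 left the value at the limit, so no size and no direction can be read from them. The expected step is a step that the limit leaves unreadable from compound 3 to compound 4, meaning nothing beyond the scatter. Compound 4 is estimated at 60000 nM, with a range from 30000 nM to 150000 nM, and the assay is expected most likely to report a limit again rather than a number.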

Compound 4, half-maximal inhibitory concentration: > 50000 nM
Compound 4: a limit, no number; the forecaster's own chance of this, stated with the estimate: 85%; the middle value lies beyond the limit too.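

Compound 4 gives > 50000 nM, a limit and not a number. No step between compound 4 and compounds 1, 2 or 3 can be read, as each joins two limits: the limit of > 50000 nM in this assay, at which 4 of the 4 values shown sit.

The compounds shown leave open whether any exchange of the group on the aromatic nitrogen shifts the value at all, and in which direction.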